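The source may hold more compounds than are shown below. What is called first, only, known or untested is meant among the compounds shown, and "the series" means these compounds.

Measured compounds:
Compound 1 `Cc1ccc(NS(=O)(=O)c2cccc(CCCCCCNC(=O)/C=C/c3cccnc3)c2)cc1` gives 9.78 nM in an assay on isolated protein for inhibition of Nicotinamide phosphoribosyltransferase (Homo sapiens), read by WST assay, with stated times of 60 min, 5 min and 30 min, in the presence of a further agent that is not named here; on this read-out higher numbers stand for weaker inhibition and lower numbers for stronger inhibition.
Compound 2 `O=C(/C=C/c1cccnc1)NCCCCCCc1cccc(S(=O)(=O)Nc2ccc(Cl)cc2)c1` gives 10.8 nM in this assay.

Compound 2 holds the highest of the two numbers, but its nearest neighbour, compound 1, lies within the scatter of it, so the two cannot be told apart on this read-out. Among the compounds with values here, the one measured step, a 1.1-fold higher number from compound 1 to compound 2 (0.04 log units; within the scatter), shows that putting chloro in place of methyl on an aromatic carbon left the number essentially unchanged. Compound 3 `O=C(/C=C/c1cccnc1)NCCCCCCc1cccc(S(=O)(=O)Nc2ccc(Oc3ccccc3)cc2)c1` has not yet been measured. It carries the change (phenoxy in place of chloro on an aromatic carbon). Within the data shown here, the phenoxy group is far larger than the chloro it replaces, so the single measured step, which compares two small groups at that place, is only a weak guide: it suggests that a substituent is tolerated there, but says nothing about a group of this size, in either direction. Compound 3 is therefore expected to give about 15 nM, with an estimated range from 4 nM to 60 nM, which corresponds to an expected step of a 1.4-fold higher number from compound 2 to compound 3 (0.14 log units; within the scatter) and leaves room for movement either way.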

Compound 3, half-maximal inhibitory concentration: 13.1 nM
Beside the measured number, compound 3's estimate is 1.1-fold (0.06 log units) above it; the range from low to high includes it.
By their numbers in this assay, from the lowest: compounds 1, 2 and 3 (each within the scatter of the next).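

In this assay, replacing the chloro with phenoxy swaps 1 heavy atom for 7 heavy atoms and adds a six-membered aromatic ring, yet it gives a 1.2-fold higher number from compound 2 to compound 3 (0.08 log units; within the scatter), so this place, para to a large group, carries a far bulkier substituent with no difference that this read-out can resolve. Set against the methyl group, phenoxy gives a 1.3-fold higher number from compound 1 to compound 3 (0.13 log units; within the scatter), which means that methyl, chloro and phenoxy cannot be told apart here, and the tolerance seen earlier for two small groups now extends to a large one. No supporting measurement is available to account for this tolerance.

On these data alone, whether the same holds for an amine, a carboxylic acid or a benzyloxy group at this place remains open, and so does the point at which a still larger group would begin to shift the number. These three compounds vary only this one substituent, so they also say nothing about how changes elsewhere in the shared core, such as a shorter or longer chain, would compare.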